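Swapping a bridged diamine for a dimethylpiperazine

The source may hold more compounds than are shown below. What is called first, only, known or untested is meant among the compounds shown, and "the series" means these compounds.

Compound 2 `CN(C[C@H]1Cc2c(cccc2N2C[C@@H]3C[C@H]2CN3)CN1)[C@H]1CCCc2cccnc21` gives the highest of the three values in an ADME assay on microsomes from liver (Homo sapiens) for metabolic stability, read by LC-MS, with a stated time of 10 min (a higher number here means that more of the compound is left, a lower number that less of the compound is left), at 100%. Compound 1 `c1cnc2c(c1)CCC[C@@H]2N(CC1CC1)C[C@H]1Cc2c(cccc2N2CCNCC2)CN1` gives 82.1% and compound 3 `FC1(F)CCC(CN(C[C@H]2Cc3c(cccc3N3CCNCC3)CN2)[C@H]2CCCc3cccnc32)CC1` gives 68.6%. Compound 4 `CN(C[C@H]1Cc2c(cccc2N2CCNC(C)(C)C2)CN1)[C@H]1CCCc2cccnc21` differs from compound 2 in one place: a group of 8 heavy atoms (6 carbon, 2 nitrogen; one six-membered non-aromatic ring with 2 hetero atoms) in place of a group of 7 heavy atoms (5 carbon, 2 nitrogen; 2 five-membered non-aromatic rings with 1 hetero atom each), on an aromatic carbon. For the measured compounds named here, the only measured step, a number 13.5 percentage points lower from compound 1 to compound 3 (beyond the scatter), concerns a different part of the molecule, so no step bears directly on this change. Compound 1 carries a plain piperazine on the same aromatic carbon as compound 4, yet it also differs from compound 2 in a second place, so its value offers only a loose hint. Compound 4 is therefore expected to stay high while losing a little, with an estimated step of a number 12 percentage points lower from compound 2 to compound 4 (beyond the scatter). The estimate for compound 4 is 88%, within 70% to 100%.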

Compound 4, percent of the compound remaining: 100%
Estimate against measurement, compound 4: 12 percentage points below, within the range that was stated.
By their numbers in this assay, from the lowest: compound 3; then compound 1; then compounds 2 and 4 (each within the scatter of the next).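

On an aromatic carbon of the shared core, 3,3-dimethylpiperazin-1-yl can take the place of the bridged diamine, with no change at the digits printed from compound 2 to compound 4 (within the scatter) in this assay. For this pair, then, holding the value does not depend on the two five-membered rings or the two defined stereocentres of the bridged group. Nothing available explains this result. As far as these compounds go, how a morpholine or a 4-methylpiperazin-1-yl group would fare on this carbon remains open. So does whether the same change would hold in other assays.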